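Changing one group on compound 2

A few compounds are considered here, and "the series" means these few. Any claim that something is new, unique, unknown or untested is made for them only; others in the source may bear on it.

In a functional assay on Ishikawa cells (Homo sapiens) for antiproliferative activity, read by CCK-8 assay, with a stated time of 48 h (on this read-out higher numbers stand for weaker inhibition and lower numbers for stronger inhibition), compound 2 (`CN(C)C(=O)/C=C/CN1CC(Oc2ccc(Oc3c(-c4ccc(F)cc4)sc4cc(O)ccc34)cc2)C1`) gives 11200 nM. Among the measured compounds shown here, the only other measured compound, compound 1 (`C/C=C/C(=O)N1CC(Oc2ccc(Oc3c(-c4ccc(F)cc4)sc4cc(O)ccc34)cc2)C1`), gives 9400 nM, and these two numbers lie within the scatter of each other, so neither can be ranked above the other.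

Compound 3 (`C=C(C)C(=O)N1CC(Oc2ccc(Oc3c(-c4ccc(F)cc4)sc4cc(O)ccc34)cc2)C1`) keeps the shared core and changes one group: (1-methylethenyl)carbonyl in place of 3-(dimethylcarbamoyl)prop-2-en-1-yl on an amine nitrogen in a ring. In words, (1-methylethenyl)carbonyl takes the place of 3-(dimethylcarbamoyl)prop-2-en-1-yl on an amine nitrogen in a ring.

For the measured compounds named here, one measured step bears on this change, at the same place: a 1.2-fold higher number from compound 1 to compound 2 (0.08 log units; within the scatter). That step put the same chain in place of (prop-1-en-1-yl)carbonyl and stayed within the scatter. The group entering compound 3 is, by name, a close relative of the group on compound 1, so a number near the 9400 nM of compound 1 is expected. Going by the values given here, this single step is the only evidence, and no measured compound carries the new group.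

The expected step is a 1.2-fold lower number from compound 2 to compound 3 (0.07 log units; within the scatter), which means no change beyond the scatter. For compound 3 the estimated value is 9500 nM, with an expected range of 4500 nM to 19000 nM.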

Compound 3, half-maximal inhibitory concentration: 14200 nM
Compound 3: the middle estimate sits 1.5-fold (0.17 log units) below what was measured; measured number inside the range.
By their numbers in this assay, from the lowest: compounds 1, 2 and 3 (each within the scatter of the next).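

In this assay, replacing the 3-(dimethylcarbamoyl)prop-2-en-1-yl chain on the amine nitrogen of the four-membered ring with (1-methylethenyl)carbonyl gives a 1.3-fold higher number from compound 2 to compound 3 (0.10 log units; within the scatter). The closer comparison, 1-methylethenyl in place of prop-1-en-1-yl on a carbonyl carbon, gives a 1.5-fold higher number from compound 1 to compound 3 (0.18 log units; within the scatter), so the two related carbonyl groups cannot be told apart here either. Three different groups have now been read on this nitrogen, one with a chain of 8 heavy atoms and one with 5 among them, and none separates from the others beyond the scatter.

Nothing measured here accounts for why these three groups read alike. The compounds shown leave open whether any group on this nitrogen would move the number beyond the scatter, such as a plain acetyl, a longer chain ending in an amine or a carboxylic acid, or a bare hydrogen on the nitrogen.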